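This account rests on a few compounds, and the source may have more. Where it says the series, first, only, none or still open, it means among the compounds named here.

Compound 3 `CC(Cc1ccc(NCc2cccc(Oc3ccccc3)c2)cc1)C(=O)O` gives 100 nM in a functional assay on CHO cells for agonist activity at Free fatty acid receptor 1 (Homo sapiens) (on this read-out lower numbers stand for an effect already at smaller amounts and higher numbers for an effect only at larger amounts of compound), and so holds the lowest of the two plain numbers in this small set. Compound 1 `O=C(O)COc1ccc(NCc2cccc(Oc3ccccc3)c2)cc1` gives 2040 nM in this assay, and the step of a 20-fold lower number from compound 1 to compound 3 (1.31 log units; beyond the scatter) is a large one. For compound 2 `CC(C)(Oc1ccc(NCc2cccc(Oc3ccccc3)c2)cc1)C(=O)O` this assay returns only a limit, < 10000 nM, and the limit of < 10000 nM in this assay, at which 1 of the 3 values shown sits, leaves every step to or from compound 2 unreadable. Compound 4 `O=C(O)[C@@H]1C[C@H]1c1ccc(NCc2cccc(Oc3ccccc3)c2)cc1` differs from compound 3 by 2-carboxycyclopropyl in place of 2-carboxypropyl on an aromatic carbon. Among the measured compounds shown here, no measured step bears directly on this change; the step from compound 1 to compound 3 only shows that a carbon-linked acid side chain at this position gives the lower number. The value for compound 4 is therefore expected to move little, a step of a 1.7-fold lower number from compound 3 to compound 4 (0.22 log units; within the scatter). The estimate for compound 4 is 60 nM, within a range of 15 nM to 300 nM.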

Compound 4, half-maximal effective concentration: 562 nM
Estimate against measurement, compound 4: 9.4-fold (0.97 log units) below; measured number above the stated range.
By their numbers in this assay, from the lowest: compound 3; then compound 4; then compound 1.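

Putting 2-carboxycyclopropyl in place of 2-carboxypropyl on this aromatic carbon gives a 5.6-fold higher number from compound 3 to compound 4 (0.75 log units; beyond the scatter), so these two carbon-linked acid side chains are not interchangeable in this assay. The same group in place of carboxymethoxy gives a 3.6-fold lower number from compound 1 to compound 4 (0.56 log units; beyond the scatter), so compound 4 keeps part of the gain that compound 3 shows over compound 1. Steps involving compound 2 cannot be read, as its value is only a limit: the limit of < 10000 nM in this assay, at which 1 of the 4 values shown sits.

Open, from the compounds shown here alone, is how the other stereoisomers of the 2-carboxycyclopropyl group would read. Also open, going by these compounds, is whether a longer chain ending in a carboxylic acid, or an amide in place of the acid, would hold the number at this position.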